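A few compounds are considered here, and "the series" means these few. Any claim that something is new, unique, unknown or untested is made for them only; others in the source may bear on it.

Compound 3 `C=CC1=C(C(=O)NCc2ccccc2)C(c2ccc(F)cc2)OC1` is one of a small set of amides sharing a common core. In a functional assay on A549 cells (Homo sapiens) for cytotoxicity, read by MTT assay, with a stated time of 24 h (on this read-out higher numbers stand for weaker inhibition and lower numbers for stronger inhibition), compound 3 reaches only the limit of > 100000 nM. Compound 1 `C=CC1=C(C(=O)NCCCCC)C(c2ccc(Cl)c(Cl)c2)OC1` likewise stops at the limit of > 100000 nM. Compound 2 `C=CC1=C(C(=O)Nc2ccccc2OC)C(c2ccc(Cl)c(Cl)c2)OC1` also stops at the limit of > 100000 nM. Within the data shown here, the single measured step, a step that the two limits leave unreadable from compound 1 to compound 2, cannot be sized because both of its ends sit at the limit (the limit of > 100000 nM in this assay, at which 3 of the 3 values shown sit). Compound 4 `C=CC1=C(C(=O)NCc2ccccc2)C(c2ccc(Cl)c(Cl)c2)OC1` differs from compound 3 by 3,4-dichlorophenyl in place of 4-fluorophenyl on a saturated ring carbon. Among the measured compounds shown here, no measured step touches the group changed here, so the move is expected to stay within the scatter, and the expected step is a step that the limit leaves unreadable from compound 3 to compound 4. Compound 4 is therefore estimated at about 120000 nM, in a range from 40000 nM to 400000 nM, most probably reported again only as a limit.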

Compound 4, half-maximal inhibitory concentration: > 100000 nM
Compound 4 was reported as a limit; the forecaster's own chance of this, stated with the estimate: 85%; the middle value does not contradict the limit.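

No step to compound 4 can be read from compound 1, compound 2 or compound 3, because both ends of each step are limits: the limit of > 100000 nM in this assay, at which 4 of the 4 values shown sit.

The compounds shown leave open which change to the shared core, if any, would give a readable value in this assay.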